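From compound 3 to compound 4: a step among limits

This account rests on a few compounds, and the source may have more. Where it says the series, first, only, none or still open, it means among the compounds named here.

Measured in an ADME assay on RAW264.7 cells (Mus musculus) for cytotoxicity, read by MTT assay, with a stated time of 24 h, in the presence of a further agent that is not named here; a lower number here means a stronger inhibitor, a higher number a weaker inhibitor:
Compound 1 `CCOCCOc1ccc(C(O)C2OC(=O)c3c(OC)cc(OC)cc32)cc1` gives > 40000 nM as a limit
Compound 2 `COc1cc(OC)c2c(c1)C(C(O)c1ccc(OCc3ccc(F)cc3)cc1)OC2=O` gives > 40000 nM as a limit
Compound 3 `COc1cc(OC)c2c(c1)C(C(O)c1ccc(OCc3ccc(OC(F)(F)F)cc3)cc1)OC2=O` gives > 40000 nM as a limit

Compound 3 has no exact number, only a limit, and it shares that position with the other two compounds. Compound 4 `COc1cc(OC)c2c(c1)C(C(O)c1ccc(OCC3CCCCC3)cc1)OC2=O` differs from it as follows: cyclohexyl in place of 4-(trifluoromethoxy)phenyl on a saturated chain carbon bound to an oxygen on an aromatic ring. In words, cyclohexyl replaces 4-(trifluoromethoxy)phenyl on a saturated chain carbon bound to an oxygen on an aromatic ring.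

For the measured compounds named here, three measured steps bear on this change. Two alter the same place: a step that the two limits leave unreadable from compound 1 to compound 2 and a step that the two limits leave unreadable from compound 1 to compound 3 are the results there. The third, with trifluoromethoxy in place of fluoro on an aromatic carbon, is a step that the two limits leave unreadable from compound 2 to compound 3 as well. None therefore gives a size.

For compound 4, no step beyond the scatter is expected in this assay because the limit of > 40000 nM in this assay, at which 3 of the 3 values shown sit, is shared by compound 1, compound 2 and compound 3 alike. The expected change is a step that the limit leaves unreadable from compound 3 to compound 4 and no larger. Compound 4 is estimated at 50000 nM with an expected range from 25000 nM to 100000 nM and will probably be reported as a limit again.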

Compound 4, half-maximal inhibitory concentration: > 40000 nM
Compound 4 gave a limit, no number; the forecaster's own chance of this, stated with the estimate: 85%; the middle value lies beyond the limit too.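

In this assay compound 4 gives > 40000 nM, a limit and not a number. For the compounds shown here, no step from compound 1, compound 2 or compound 3 to compound 4 can be read. The compounds shown leave open whether any group at this place would give a measurable half-maximal inhibitory concentration.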